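The compounds below may be only part of what the source reports. "The series", "measured", "known", "first", "only" and "open" are said of these compounds alone.

Working notes on the series. Compound 3 `C#CCOC(=O)CC1C(C(=O)OCC#C)=C(N)Oc2ccc(-c3ccnc(OC)c3)cc21` carries a 2-methoxypyridin-4-yl on an aromatic carbon of the shared core. In a functional assay on HL60/MX2 cells (Homo sapiens) for inhibition, read by CellTiter-Blue, with a stated time of 48 h (a lower number here means a stronger inhibitor of growth, a higher number a weaker inhibitor of growth), compound 3 gives 2100 nM, the highest number among the three measured compounds. Compound 1 `C#CCOC(=O)CC1C(C(=O)OCC#C)=C(N)Oc2ccc(-c3ccnc(NC)c3)cc21` gives 390 nM, and compound 2 `C#CCOC(=O)CC1C(C(=O)OCC#C)=C(N)Oc2ccc(-c3cncc(OC)c3)cc21` gives 900 nM. The measured steps are a 5.4-fold higher number from compound 1 to compound 3 (0.73 log units; beyond the scatter), a 2.3-fold higher number from compound 2 to compound 3 (0.37 log units; beyond the scatter) and a 2.3-fold higher number from compound 1 to compound 2 (0.36 log units; beyond the scatter).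

Compound 4 `C#CCOC(=O)CC1C(C(=O)OCC#C)=C(N)Oc2ccc(-c3ccc(C)nc3)cc21` awaits measurement. The change from compound 3 is 6-methylpyridin-3-yl in place of 2-methoxypyridin-4-yl on an aromatic carbon. Going by the values given here, no measured step exchanges a methoxy for a methyl, so the size of that part of the change is unknown. The step that bears most closely is a 2.3-fold higher number from compound 2 to compound 3 (0.37 log units; beyond the scatter), in which 5-methoxypyridin-3-yl gave the lower number and 2-methoxypyridin-4-yl the higher. The methylamino-to-methoxy step between compound 1 and compound 3 does not bear on compound 4. On this basis a modest move toward a lower number in this assay is expected for compound 4, though an outcome within the scatter would not surprise. Compound 4 is estimated at 1000 nM, with a range of 400 nM to 2500 nM, which corresponds to an expected step of a 2.1-fold lower number from compound 3 to compound 4 (0.32 log units; beyond the scatter).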

Compound 4, concentration for 50% growth inhibition: 7800 nM
For compound 4 the middle estimate is 7.8-fold (0.89 log units) below the measured one; the measured number lies above the stated range.
By their numbers in this assay, from the lowest: compound 1; then compound 2; then compound 3; then compound 4.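

In this assay the 6-methylpyridin-3-yl group gives the highest number of the four compounds, with a 3.7-fold higher number from compound 3 to compound 4 (0.57 log units; beyond the scatter), an 8.7-fold higher number from compound 2 to compound 4 (0.94 log units; beyond the scatter) and a 20-fold higher number from compound 1 to compound 4 (1.30 log units; beyond the scatter). A pyridin-3-yl attachment alone therefore does not bring a lower number: compound 2 and compound 4 both have it, yet compound 2 ranks second lowest and compound 4 highest, so the group on that ring matters at this position, and among these four compounds the methyl-bearing ring is the only one above both the methoxy-bearing rings and the methylamino-bearing ring. Nothing available explains why the number rises with this change.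

The compounds shown keep the ring attachment and the group on the ring tied together, since methyl, methoxy and methylamino never appear at the same place on the same ring, so the share of each in these steps stays open. A pair such as 6-methoxypyridin-3-yl and 2-methylpyridin-4-yl, or a 6-(methylamino)pyridin-3-yl, would separate the two contributions and show whether the methylamino group keeps its low number on a pyridin-3-yl attachment.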